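From methyl ester to isopropyl amide at the limit

The source may report more compounds than this note shows. Statements on the series, on what has been measured and on what is new or still open speak of the compounds shown alone.

In a functional assay on cells (Platelet, Homo sapiens) for inhibition (on this read-out higher numbers stand for weaker inhibition and lower numbers for stronger inhibition), three compounds have been measured, each value being a limit and not a number:
- compound 1 `CCOC(=O)c1ccc(-c2nn(Cc3ccccc3Cl)c3ccccc23)cc1` gives > 10000 nM as a limit
- compound 2 `CCCCn1nc(-c2ccc(C(=O)OCC)cc2)c2ccccc21` gives > 10000 nM as a limit
- compound 3 `COC(=O)c1ccc(-c2nn(Cc3ccccc3)c3ccccc23)cc1` gives > 10000 nM as a limit

Compound 3 therefore has no exact position, and no order can be read among the three. The evidence so far is the limit of > 10000 nM in this assay, at which 3 of the 3 values shown sit, and nothing finer.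

The change to compound 4 `CC(C)NC(=O)c1ccc(-c2nn(Cc3ccccc3)c3ccccc23)cc1` is isopropylamino in place of methoxy on a carbonyl carbon and turns methoxycarbonyl into isopropylcarbamoyl. Among the measured compounds shown here, the only measured step is a step that the two limits leave unreadable from compound 1 to compound 2 and it offers no size to carry over. It also lies at a different place in the structure. No step beyond the scatter is therefore expected in this assay and another reported limit is the likeliest result for compound 4. As a number, the expected change is a number no higher from compound 3 to compound 4 (the limit leaves the size open) in this estimate. The estimated value for compound 4 is 10000 nM with an expected range from 3000 nM to 30000 nM as its upper end.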

Compound 4, half-maximal inhibitory concentration: > 10000 nM
Compound 4: only a limit was reported (the forecaster's own chance of this, stated with the estimate: 80%); the middle value sits exactly at the limit.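

Compound 3 and compound 4 are both reported only as limits and not as numbers, so the step from methoxy to isopropylamino cannot be read. The compounds shown leave open how strongly, if at all, any of them inhibits, as the record holds only this: the limit of > 10000 nM in this assay, at which 4 of the 4 values shown sit.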